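Amide variation on a dimethoxy-fused acetamide core

The source may report more compounds than this note shows. Statements on the series, on what has been measured and on what is new or still open speak of the compounds shown alone.

Measured so far:
compound 1 `COc1cc2c(cc1OC)C(CC(=O)NC(C)(C)C)CC2` — 32%
compound 2 `COc1cc2c(cc1OC)C(CC(=O)N1CCCC1)CC2` — 20%

Both compounds were examined in a functional assay on the whole organism (strain Wistar) for inhibition, with Rattus norvegicus as the target, read by paw edema, with stated times of 60 min and 2 h, at a dose of 100 mg/kg by the oral route; on this read-out lower numbers stand for less inhibition and higher numbers for more inhibition at the one dose given (going by the name of the read-out). Going by the values given here, compound 1 gives 32% and compound 2 gives 20%, which places compound 2 as the lower of the two numbers, with compound 1 its only neighbour. Among the compounds with values here, the one measured step, a number 12 percentage points lower from compound 1 to compound 2 (beyond the scatter), is the sole guide available for this series.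

Compound 3 `COc1cc2c(cc1OC)C(CC(=O)N1CCCCC1)CC2` has not yet been measured. The change is piperidin-1-yl in place of pyrrolidin-1-yl on a carbonyl carbon. Within the data shown here, no measured step concerns the same kind of change, a ring of one size exchanged for a ring of the next size at the amide; the single step known exchanges a branched open-chain amine for a ring amine, and it was modest. With only that to go on, the expected outcome for compound 3 is a step of a number 2 percentage points higher from compound 2 to compound 3 (within the scatter), not clearly beyond the scatter in either direction. Compound 3 is therefore estimated at 22%, with a range from 8% to 40%.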

Compound 3, a percentage reported as inhibition, in the whole organism at one dose (the size of the read-out at that dose, not a potency): 22%
Estimate against measurement, compound 3: no gap at the digits printed, and the stated range covers the measured number.
By their numbers in this assay, from the lowest: compounds 2, 3 and 1 (each within the scatter of the next, the first and the last beyond it).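

In this assay, the only ring-for-ring exchange shown at this position, piperidin-1-yl in place of pyrrolidin-1-yl on a carbonyl carbon, gives a number 2 percentage points higher from compound 2 to compound 3 (within the scatter) and so does not separate these two ring amides. Piperidin-1-yl in place of (tert-butyl)amino gives a number 10 percentage points lower from compound 1 to compound 3 (within the scatter), so this ring amide, unlike the pyrrolidin-1-yl amide of compound 2, is not separated from the open-chain amide of compound 1. Nothing available bears on the reason for these readings.

From the compounds shown here alone, whether azetidin-1-yl, morpholin-4-yl or a straight-chain butylamino group on the same carbonyl carbon would read differently stays open. The shared core is the same throughout the compounds shown, so a change there, such as hydroxy in place of methoxy, also stays open.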